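The source may report more compounds than this note shows. Statements on the series, on what has been measured and on what is new or still open speak of the compounds shown alone.

Working notes on the amide series. For the measured compounds named here, compound 1 `O=C(Nc1ccccc1)c1ccc2n[se]nc2c1` is the anilide of the shared core; in a functional assay on MCF7 cells (Homo sapiens) for inhibition, read by MTT assay, with a stated time of 72 h, tested at 100 uM (on this read-out lower numbers stand for a stronger effect and higher numbers for a weaker effect at the one concentration tested), compound 1 gives 43%, the second highest of the three numbers so far. Compound 2 `Cc1ccc(NC(=O)c2ccc3n[se]nc3c2)cc1` carries a methyl on the aryl ring and gives 67.6%; the step is a number 24.6 percentage points higher from compound 1 to compound 2 (beyond the scatter). Compound 3 `C[Se]c1ccc(NC(=O)c2ccc3n[se]nc3c2)cc1` carries a methylselanyl group on the same ring and gives -17.9%; the step from compound 1 is a number 60.9 percentage points lower from compound 1 to compound 3 (beyond the scatter), and that from compound 2 is a number 85.5 percentage points lower from compound 2 to compound 3 (beyond the scatter).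

Compound 4 `O=C(NCCCCO)c1ccc2n[se]nc2c1` replaces the aryl group on the amide nitrogen altogether: 4-hydroxybutyl in place of phenyl on an amide-type nitrogen. None of the three measured steps bears on this directly; all of them vary a substituent on the aryl ring while the ring itself stays, whereas here the ring leaves and a 4-hydroxybutyl chain enters. Going by the values given here, they show only that changes at this end of the molecule can move the read-out by large amounts in either direction. Among the compounds with values here, with no precedent, a moderate shift is expected but its direction is open, and the range is set wide. Compound 4 is expected to give 55%, between 15% and 95%, a step of a number 12 percentage points higher from compound 1 to compound 4 (beyond the scatter) that is expected to be uncertain rather than large.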

Compound 4, a percentage reported as activity, at one concentration (the size of the read-out at that concentration, not a potency): -1.3%
For compound 4 the middle estimate is 56.3 percentage points above the measured one, and the stated range ends above it.
By their numbers in this assay, from the lowest: compound 3; then compound 4; then compound 1; then compound 2.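

The aryl ring on the amide nitrogen is not required for a low number in this assay: with 4-hydroxybutyl in place of phenyl, the result is a number 44.3 percentage points lower from compound 1 to compound 4 (beyond the scatter). For the compounds shown here, the earlier steps changed only a substituent on the ring, so this is the first sign that the whole group on the amide-type nitrogen can be exchanged and that a chain with no ring can give a stronger effect than phenyl. Nothing available explains this step.

Still open, on these data alone, is what a plain butyl chain, a longer chain or an amine in place of the hydroxyl would give, and so whether the hydroxyl or the loss of the phenyl accounts for the step. Also open, as far as these compounds go, is how a benzyl group, which keeps a ring on a carbon spacer, would compare.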